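The compounds below may be only part of what the source reports. "The series", "measured", "known", "first", "only" and "open" are said of these compounds alone.

Working notes on the series.

Compound 1 `N/C(=N\NC(=S)N1CCCCCC1)c1ccccn1` carries a seven-membered saturated ring on the thiourea nitrogen; in a functional assay on HeLa cells (Homo sapiens) for cytotoxicity, read by MTT assay, with a stated time of 72 h, tested at 1 uM (a lower number here means less inhibition of growth, a higher number more inhibition of growth at the concentration tested), compound 1 gives 21.3%. Compound 2 `N/C(=N\NC(=S)N1CCSCC1)c1ccccn1` differs from compound 1 in the ring on that nitrogen; the difference between the two cores is not broken down here. In this assay compound 2 gives 25.1%, and the two values lie within the usual scatter of each other. Compound 3 `N/C(=N\NC(=S)N1CCSCC1)c1ccc(F)cn1` carries the same change that separates compound 1 from compound 4: fluoro in place of hydrogen on an aromatic carbon. In this assay compound 3 gives 19.6%, a step of a number 5.5 percentage points lower from compound 2 to compound 3 (within the scatter), within the scatter.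

Compound 4 `N/C(=N\NC(=S)N1CCCCCC1)c1ccc(F)cn1` is the unmeasured member; its change from compound 1 is fluoro in place of hydrogen on an aromatic carbon, the same change as from compound 2 to compound 3, with the same surroundings. For the measured compounds named here, the only guide is the step from compound 2 to compound 3, a number 5.5 percentage points lower from compound 2 to compound 3 (within the scatter), so a step of similar size, a number 3.8 percentage points lower from compound 1 to compound 4 (within the scatter), is expected from compound 1 to compound 4, with compound 1 at 21.3% as the starting point. Compound 4 is therefore estimated to give 17.5% in this assay, expected between 8% and 28%.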

Compound 4, percent growth inhibition at one concentration: 50%
The estimate for compound 4 lay 32.5 percentage points below the measured number; measured number above the stated range.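

In this assay, fluoro in place of hydrogen on an aromatic carbon gives a number 28.7 percentage points higher from compound 1 to compound 4 (beyond the scatter), while on the core of compound 2 the same change gives a number 5.5 percentage points lower from compound 2 to compound 3 (within the scatter), so the step measured on one core does not predict the step on the other: the same change on two cores in this assay, a number 5.5 percentage points lower (within the scatter) from compound 2 to compound 3 and a number 28.7 percentage points higher (beyond the scatter) from compound 1 to compound 4, 34.2 percentage points apart, beyond the scatter of two such steps

The fluoro step therefore depends on the core in this pair of comparisons, with the larger step seen on the core with the seven-membered saturated ring. For the compounds shown here, this does not show why the two steps differ, and with only two pairs, each read at a single concentration, it gives no rule for any further core.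

The compounds shown leave open whether the gain on the core of compound 1 is specific to fluoro or also appears with chloro, methoxy or an amine in the same place. They also leave open how the fluoro step behaves on cores carrying other groups on the thiourea nitrogen, such as an open alkyl chain.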